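A few compounds are considered here, and "the series" means these few. Any claim that something is new, unique, unknown or untested is made for them only; others in the source may bear on it.

Within the data shown here, in a functional assay on BXPC-3 cells (Homo sapiens) for antiproliferative activity, read by MTT assay, with a stated time of 24 h (on this read-out lower numbers stand for stronger inhibition and higher numbers for weaker inhibition), compound 2 `CCn1c(C(=O)N[C@H](C)CO)ccc1C(CC)(CC)c1ccc(OCS(=O)(=O)c2ccccc2)c(C)c1` gives 10000 nM, the only number in this set. Compound 1 `CCn1c(C(=O)NCCNC(=O)OC(C)(C)C)ccc1C(CC)(CC)c1ccc(OCS(=O)(=O)c2ccccc2)c(C)c1` reaches only the assay limit, > 50000 nM. Compound 3 `CCn1c(C(=O)NCC(=O)O)ccc1C(CC)(CC)c1ccc(OCS(=O)(=O)c2ccccc2)c(C)c1` likewise sits at the assay limit, > 50000 nM. Two of the three values thus sit at the limit of > 50000 nM in this assay, at which 2 of the 3 values shown sit. Compound 4 `CCn1c(C(=O)NC2(C(=O)O)CC2)ccc1C(CC)(CC)c1ccc(OCS(=O)(=O)c2ccccc2)c(C)c1` has not yet been measured; it differs from compound 2 in one place: 1-carboxycyclopropyl in place of 1-(hydroxymethyl)ethyl on an amide-type nitrogen. The nearest measured step is the one in which a carboxymethyl group took the place of the 1-(hydroxymethyl)ethyl group, an at least 5.0-fold higher number from compound 2 to compound 3 (0.69 log units; beyond the scatter); the step in the other direction, an at least 5.0-fold lower number from compound 1 to compound 2 (0.69 log units; beyond the scatter), shows that compound 2 alone left the limit. Since compound 4 also carries a carboxy group, a step of similar direction is expected, and the estimate is a 5.0-fold higher number from compound 2 to compound 4 (0.70 log units; beyond the scatter). Compound 4 is therefore expected to give about 50000 nM in this assay, between 15000 nM and 150000 nM, quite possibly reported only as a limit.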

Compound 4, half-maximal inhibitory concentration: > 50000 nM
Compound 4: no number, only a limit; the forecaster's own chance of this, stated with the estimate: 70%; the middle value lies on the limit itself.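

Putting 1-carboxycyclopropyl in place of 1-(hydroxymethyl)ethyl on the amide-type nitrogen also costs activity in this assay (an at least 5.0-fold higher number from compound 2 to compound 4 (0.69 log units; beyond the scatter)). The loss therefore does not belong to carboxymethyl alone: a second carboxy-bearing group, this one with a three-membered ring, leaves compound 4 at a limit rather than a number. Compound 1, which has no carboxy group, stands at a limit too, so only compound 2 gives a measurable value: (the limit of > 50000 nM in this assay, at which 3 of the 4 values shown sit).

As far as these compounds go, the steps among compounds 1, 3 and 4 cannot be read, so what the ring does on its own stays open. A 1-(hydroxymethyl)cyclopropyl group would separate the ring from the carboxy group, and an amine or a longer alcohol chain on this nitrogen could show whether anything improves on compound 2.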